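The compounds below may be only part of what the source reports. "The series", "measured", "known", "first", "only" and "open" are said of these compounds alone.

Compound 2, `COc1ccc(-c2cc3cc(-c4ccc(F)cc4)cc(C(C)=O)c3[nH]2)cc1`, was tested in a functional assay on MCF7 cells (Homo sapiens) for cytotoxicity, read by MTT assay, with a stated time of 2 days, tested at 100 uM (a higher number here means a weaker effect of the compound at the concentration tested, a lower number a stronger effect), and gave 47%. Among the compounds with values here, it stands alongside compound 1, `COc1ccc(-c2cc3cc(-c4ccccc4)cc(C(C)=O)c3[nH]2)cc1`, which in this assay gave 43.5%; the only measured step, a number 3.5 percentage points higher from compound 1 to compound 2 (within the scatter), is a swap at the same aromatic carbon that compound 3 now changes again. Compound 3, `COc1ccc(-c2cc(C(C)=O)c3[nH]c(-c4ccc(OC)cc4)cc3c2)cc1`, differs from compound 2 by methoxy in place of fluoro on an aromatic carbon. Within the data shown here, no measured step covers methoxy in place of fluoro, and the one nearby step stayed within the scatter, so the expected step is no change at the digits printed from compound 2 to compound 3 (within the scatter). Compound 3 is estimated at 47%, between 34% and 61%.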

Compound 3, a percentage reported as activity, at one concentration (the size of the read-out at that concentration, not a potency): 39.9%
Beside the measured number, compound 3's estimate is 7.1 percentage points above it, within the range that was stated.
By their numbers in this assay, from the lowest: compounds 3, 1 and 2 (each within the scatter of the next).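

Methoxy in place of fluoro gives a number 7.1 percentage points lower from compound 2 to compound 3 (within the scatter) and methoxy in place of hydrogen gives a number 3.6 percentage points lower from compound 1 to compound 3 (within the scatter) in this assay at this aromatic carbon. Hydrogen, fluoro and methoxy there therefore read alike across these three compounds, so even the larger of these groups brings no step beyond the scatter. Nothing at hand offers a reason for this reading.

Still open, as far as these compounds go, is whether an amine, a carboxylic acid or a longer chain at this carbon would move the number beyond the scatter. Changes elsewhere on the shared core also remain open.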